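The source may hold more compounds than are shown below. What is called first, only, known or untested is meant among the compounds shown, and "the series" means these compounds.

Working notes on the series. Compound 1 `COc1cc(-c2nnc(SCC(=O)c3cccc(Br)c3)n2N)cc(OC)c1OC` carries a 3-bromophenyl ketone on the thioacetyl arm of the shared core; in a functional assay on HepG2 cells (Homo sapiens) for antiproliferative activity, read by MTT assay, with a stated time of 48 h (a higher number here means a weaker inhibitor, a lower number a stronger inhibitor), compound 1 gives 56000 nM. Compound 2 `COc1cc(-c2nnc(SCC(=O)Nc3ccccc3)n2N)cc(OC)c1OC` has an anilino group on the same carbonyl carbon, and in this assay compound 2 gives 49900 nM; the step is a 1.1-fold lower number from compound 1 to compound 2 (0.05 log units; within the scatter). Compound 3 `COc1cc(-c2nnc(SCC(=O)Nc3ccc(C)cc3)n2N)cc(OC)c1OC` differs from compound 2 by methyl in place of hydrogen on an aromatic carbon. In this assay compound 3 gives > 100000 nM, which is a limit of the assay and not a number (the limit of > 100000 nM in this assay, at which 1 of the 3 values shown sits). On the numbers shown compound 3 therefore stands at the weak end: an at least 1.7-fold higher number from compound 1 to compound 3 (0.25 log units; that floor lies within the scatter) and an at least 2.0-fold higher number from compound 2 to compound 3 (0.30 log units; that floor lies within the scatter), both floors within the scatter. Compound 4 `COc1cc(-c2nnc(SCC(=O)NCc3ccc(C)cc3)n2N)cc(OC)c1OC` differs from compound 3 by 4-methylbenzyl in place of 4-methylphenyl on an amide-type nitrogen. For the measured compounds named here, no measured step covers this change; the nearest, an at least 2.0-fold higher number from compound 2 to compound 3 (0.30 log units; that floor lies within the scatter), stayed within the scatter, and the steps among compounds 1, 2 and 3 all did. In this assay no step beyond the scatter is expected, estimated as a step that the limit leaves unreadable from compound 3 to compound 4. Compound 4 is expected at 110000 nM, range 40000 nM to 300000 nM, most likely reported again as a limit.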

Compound 4, half-maximal inhibitory concentration: > 100000 nM
Compound 4: no number, only a limit; the forecaster's own chance of this, stated with the estimate: 60%; the middle value is on the limit's open side.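

In this assay compound 4 gives > 100000 nM, which is a limit of the assay and not a number. The step from 4-methylphenyl to 4-methylbenzyl on the amide-type nitrogen cannot be read, and the series now has a second amide at the open end of the range: the limit of > 100000 nM in this assay, at which 2 of the 4 values shown sit. Against the two compounds with readable values the result is an at least 2.0-fold higher number from compound 2 to compound 4 (0.30 log units; that floor lies within the scatter) and an at least 1.7-fold higher number from compound 1 to compound 4 (0.25 log units; that floor lies within the scatter), so neither floor separates compound 4 from them.

From the compounds shown here alone, how far compound 3 and compound 4 lie from each other stays open, as does any effect of the 4-methylbenzyl group itself. Also open, going by these compounds, is whether a longer chain such as 2-phenylethyl on the amide-type nitrogen, or an amine or a carboxylic acid in place of the methyl on the aromatic ring, would give a readable number.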